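Methoxycarbonyl in Place of Aminocarbamoyl: Expected Edema Inhibition

The compounds below may be only part of what the source reports. "The series", "measured", "known", "first", "only" and "open" are said of these compounds alone.

compound 1 `CC(=O)c1ccc(NC(=O)c2nc(-c3ccccc3)n(-c3ccc(S(N)(=O)=O)cc3)n2)cc1`: 68%
compound 2 `NC(=O)c1nc(-c2ccccc2)n(-c2ccc(S(N)(=O)=O)cc2)n1`: 48%
compound 3 `NNC(=O)c1nc(-c2ccccc2)n(-c2ccc(S(N)(=O)=O)cc2)n1`: 53%

In a functional assay on the whole organism for inhibition, with Rattus norvegicus as the target, read by paw edema, with stated times of 30 min and 2 h, at a dose of 0.28 mmol/kg by the oral route (on this read-out higher numbers stand for more inhibition at the one dose given (going by the name of the read-out) and lower numbers for less inhibition), compound 1 gives 68%, compound 2 gives 48% and compound 3 gives 53%. Compound 3 thus stands second highest of the three: the step of a number 5 percentage points higher from compound 2 to compound 3 (within the scatter) is within the scatter, while the step of a number 15 percentage points lower from compound 1 to compound 3 (beyond the scatter) is beyond it. Compound 4 `COC(=O)c1nc(-c2ccccc2)n(-c2ccc(S(N)(=O)=O)cc2)n1` is not yet measured; it differs from compound 3 by methoxy in place of aminoamino on a carbonyl carbon. The steps of a number 20 percentage points lower from compound 1 to compound 2 (beyond the scatter) and a number 15 percentage points lower from compound 1 to compound 3 (beyond the scatter) show that removing 4-acetylphenyl from the amide-type nitrogen lowers the read-out, whereas a number 5 percentage points higher from compound 2 to compound 3 (within the scatter) shows that small groups on that nitrogen hardly matter. Within the data shown here, no measured step swaps the nitrogen for methoxy, so a change within the scatter is expected. Compound 4 is therefore estimated at 48%, between 35% and 60%. This estimate means an expected step of a number 5 percentage points lower from compound 3 to compound 4 (within the scatter).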

Compound 4, a percentage reported as inhibition, in the whole organism at one dose (the size of the read-out at that dose, not a potency): 48%
Beside the measured number, compound 4's estimate shows no gap at the digits printed, and the stated range covers the measured number.
By their numbers in this assay, from the lowest: compounds 2, 4 and 3 (each within the scatter of the next); then compound 1.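

On the carbonyl carbon, a nitrogen link proves not to be needed to hold the level of the small groups in this assay: methoxy, with 0 hydrogen-bond donors, gives a number 5 percentage points lower from compound 3 to compound 4 (within the scatter) and no change at the digits printed from compound 2 to compound 4 (within the scatter). Only the large group stands apart, with a number 20 percentage points lower from compound 1 to compound 4 (beyond the scatter). Nothing available explains why these swaps behave this way. Going by these compounds, it remains open whether a carboxylic acid or a longer ester such as ethoxycarbonyl would stay level with the small groups, and whether the acetyl of the (4-acetylphenyl)amino group matters.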